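The source may hold more compounds than are shown below. What is called first, only, known or untested is meant among the compounds shown, and "the series" means these compounds.

Measured in an ADME assay on MDBK cells (Bos taurus) for cytotoxicity, read by MTT assay, with a stated time of 96 h; on this read-out higher numbers stand for lower toxicity in this test and lower numbers for higher toxicity in this test:
Compound 1 `Oc1ccc(-c2nc3cc(C(F)(F)F)ccc3[nH]2)cc1`: 51000 nM
Compound 2 `O=[N+]([O-])c1ccc(-c2nc3cc(C(F)(F)F)ccc3[nH]2)cc1`: 6000 nM

Compound 2, at 6000 nM, stands lowest of the two numbers, and so shows the higher toxicity in this test. Compound 3 `Fc1ccc(-c2nc3cc(C(F)(F)F)ccc3[nH]2)cc1` differs from it by fluoro in place of nitro on an aromatic carbon. For the measured compounds named here, one measured step bears on this change: an 8.5-fold lower number from compound 1 to compound 2 (0.93 log units; beyond the scatter), which lies beyond the scatter and brings in the same nitro group, there in place of hydroxy. Going by the values given here, no measured compound carries fluoro, so the evidence is indirect. Losing the nitro group is expected to move the number back up in this assay, by a modest step of similar or somewhat smaller size. The expected step is a 3.3-fold higher number from compound 2 to compound 3 (0.52 log units; beyond the scatter). Compound 3 is estimated at 20000 nM, with an expected range of 6000 nM to 60000 nM.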

Compound 3, half-maximal cytotoxic concentration: 19000 nM
Compound 3: the middle estimate sits 1.1-fold (0.02 log units) above what was measured; measured number inside the range.
By their numbers in this assay, from the lowest: compound 2; then compound 3; then compound 1.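

In this assay, a 3.2-fold higher number from compound 2 to compound 3 (0.50 log units; beyond the scatter) shows that the number rises when fluoro replaces nitro on this aromatic carbon, so the lower number of compound 2 is tied to the nitro group and not to the shared core alone. Yet fluoro does not bring back the higher number seen with hydroxy: a 2.7-fold lower number from compound 1 to compound 3 (0.43 log units; beyond the scatter) places the fluoro compound between the other two, and the three groups at this position give three numbers separated beyond the scatter. Nothing measured here accounts for this order.

The compounds shown leave open whether an amine, a carboxylic acid or a methoxy group at this position would fall within the span of these three numbers. They also leave open whether the same order holds with a group other than the trifluoromethyl group that all three compounds carry on the shared core.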